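The compounds below may be only part of what the source reports. "The series", "measured", "known", "first", "only" and "open" are said of these compounds alone.

For the measured compounds named here, in a toxicity assay on L02 cells (Homo sapiens) for cytotoxicity, read by MTT assay, with a stated time of 72 h (a lower number here means a stronger inhibitor, a higher number a weaker inhibitor), compound 2 `O=C1c2c[n+]([O-])c3ccccc3c2C(=O)c2c1c1ccccc1n2Cc1cn(CC(O)CO)nn1` reads 1070 nM, the higher of the two numbers so far, which makes it the weaker inhibitor of the pair. The other measured compound, compound 1 `CC1(C)OCC(Cn2cc(Cn3c4c(c5ccccc53)C(=O)c3c[n+]([O-])c5ccccc5c3C4=O)nn2)O1`, gives 120 nM. Going on to compound 3 `CC1(C)O[C@@H](CO)[C@H](Cn2cc(Cn3c4c(c5ccccc53)C(=O)c3c[n+]([O-])c5ccccc5c3C4=O)nn2)O1` alters one group on the shared core: 5-(hydroxymethyl)-2,2-dimethyl-1,3-dioxolan-4-yl in place of 1,2-dihydroxyethyl on a saturated chain carbon bound to an aromatic nitrogen. Seen one bond further out, 2,3-dihydroxypropyl gives way to (5-(hydroxymethyl)-2,2-dimethyl-1,3-dioxolan-4-yl)methyl. Going by the values given here, only one measured step bears on this change: an 8.9-fold higher number from compound 1 to compound 2 (0.95 log units; beyond the scatter), where 1,2-dihydroxyethyl replaced 2,2-dimethyl-1,3-dioxolan-4-yl on a saturated chain carbon bound to an aromatic nitrogen. Compound 3 again carries a dioxolanyl ring, so that step, read in reverse, points towards a lower number. Among the compounds with values here, the ring in compound 3 also bears a hydroxymethyl, however, and no measured compound shows what this addition does, so only part of that step is counted on. The expected change is a 3.6-fold lower number from compound 2 to compound 3 (0.55 log units; beyond the scatter). For compound 3 the estimated value is 300 nM, with an expected range of 110 nM to 800 nM.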

Compound 3, half-maximal inhibitory concentration: 500 nM
Beside the measured number, compound 3's estimate is 1.7-fold (0.22 log units) below it; the range from low to high includes it.
By their numbers in this assay, from the lowest: compound 1; then compound 3; then compound 2.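

A dioxolanyl ring on a saturated chain carbon bound to an aromatic nitrogen now lowers the number in this assay a second time, even with a hydroxymethyl on the ring, and replacing 1,2-dihydroxyethyl with the larger 5-(hydroxymethyl)-2,2-dimethyl-1,3-dioxolan-4-yl gives a 2.1-fold lower number from compound 2 to compound 3 (0.33 log units; beyond the scatter). That gain is only part of what the plain ring offers: comparing the two ring-bearing groups gives a 4.2-fold higher number from compound 1 to compound 3 (0.62 log units; beyond the scatter), so 5-(hydroxymethyl)-2,2-dimethyl-1,3-dioxolan-4-yl sits in the middle of the three groups at this place, with 2,2-dimethyl-1,3-dioxolan-4-yl giving the lowest number. No measurement here explains why the number moves in either step.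

The hydroxymethyl and the 2 defined stereocentres enter together in compound 3, so the compounds shown cannot separate what each contributes to its number. From the compounds shown here alone, it also remains open how the number would respond if an amine or a carboxylic acid took the place of the hydroxymethyl on the ring, or if a longer chain joined the ring to the triazole-bearing side of the molecule.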